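Changing the End of a Side Chain

A few compounds are considered here, and "the series" means these few. Any claim that something is new, unique, unknown or untested is made for them only; others in the source may bear on it.

Small edits at one spot on a shared core can show how sensitive a biological read-out is to that spot. In a functional assay on cells (Neutrophil, Homo sapiens) for inhibition, read by transwell migration (on this read-out higher numbers stand for weaker inhibition and lower numbers for stronger inhibition), compound 1 (`CCOC(=O)c1c(NCCN(C)C)n(-c2ccccc2)c(=S)n(-c2ccccc2)c1=O`) gives 0.1 nM and compound 2 (`CCOC(=O)c1c(NCCC2CCCN2C)n(-c2ccccc2)c(=S)n(-c2ccccc2)c1=O`) gives 1.61 nM as the higher of these two numbers. Compound 3 (`CCOC(=O)c1c(NCCOC)n(-c2ccccc2)c(=S)n(-c2ccccc2)c1=O`) has not yet been measured. It carries methoxy in place of 1-methylpyrrolidin-2-yl on a saturated chain carbon, two bonds along the chain from a nitrogen on an aromatic ring. Within the data shown here, the one measured step (a 16-fold higher number from compound 1 to compound 2 (1.21 log units; beyond the scatter)) put 1-methylpyrrolidin-2-yl in place of dimethylamino at this same place and lay beyond the scatter, so a change here can move the number a long way. Methoxy holds no nitrogen, unlike both of those groups. A single step cannot settle the direction, yet a moderate rise is the expectation here (a 3.1-fold higher number from compound 2 to compound 3 (0.49 log units; beyond the scatter)). The estimate for compound 3 is 5 nM and the expected range runs from 0.4 nM to 60 nM in this assay for this compound.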

Compound 3, half-maximal inhibitory concentration: 1.36 nM
For compound 3 the middle estimate is 3.7-fold (0.57 log units) above the measured one; measured number inside the range.
By their numbers in this assay, from the lowest: compound 1; then compounds 3 and 2 (each within the scatter of the next).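

In this assay, on a saturated chain carbon, two bonds along the chain from a nitrogen on an aromatic ring, methoxy in place of 1-methylpyrrolidin-2-yl gives a 1.2-fold lower number from compound 2 to compound 3 (0.07 log units; within the scatter), so this read-out does not separate the two groups, although methoxy has 2 heavy atoms against 6, no ring, and oxygen instead of nitrogen. Methoxy in place of dimethylamino gives a 14-fold higher number from compound 1 to compound 3 (1.13 log units; beyond the scatter), which leaves compound 1 as the only one of the three set apart from both others by steps beyond the scatter. Having a nitrogen in the group therefore does not by itself track with the number, since compound 1 and compound 2 both have one and only compound 1 stands apart, and nothing available explains these results.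

From the compounds shown here alone, it remains open whether the low number of compound 1 is tied to dimethylamino itself or would also appear with a close relative such as diethylamino or a simple methylamino group on the same chain. A longer chain carrying dimethylamino would show whether the length of the chain matters as much as the group at its end.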